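A few compounds are considered here, and "the series" means these few. Any claim that something is new, unique, unknown or untested is made for them only; others in the source may bear on it.

In a functional assay on A549 cells (Homo sapiens) for cytotoxicity, read by MTT assay, with a stated time of 48 h (a higher number here means a weaker inhibitor, a lower number a stronger inhibitor), compound 3 `CCCc1nnc(SCC(=O)c2ccc(Cl)cc2)n1N1C(=O)c2ccccc2C1=O` gives only a limit, > 200000 nM. Compound 1 `C=CCSc1nnc(CCC)n1N1C(=O)c2ccccc2C1=O` likewise returns a limit in this assay, > 200000 nM. Compound 2 `CCCc1nnc(SCc2ccccc2)n1N1C(=O)c2ccccc2C1=O` also stops at a limit in this assay, > 200000 nM. The steps a step that the two limits leave unreadable from compound 1 to compound 2, a step that the two limits leave unreadable from compound 1 to compound 3 and a step that the two limits leave unreadable from compound 2 to compound 3 therefore cannot be sized, because of the limit of > 200000 nM in this assay, at which 3 of the 3 values shown sit. Compound 4 `CCCc1nnc(SCC(=O)c2ccc(C)cc2)n1N1C(=O)c2ccccc2C1=O` differs from compound 3 by methyl in place of chloro on an aromatic carbon. For the measured compounds named here, no measured step touches this position, and the three measured values give no graded response to read against, so compound 4 is expected to sit at the same limit in this assay, with 200000 nM estimated and a range of 100000 nM to 400000 nM. The expected step of a number no higher from compound 3 to compound 4 (the limit leaves the size open) is accordingly none beyond the scatter.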

Compound 4, half-maximal inhibitory concentration: > 200000 nM
Compound 4 ended at the assay's limit; the forecaster's own chance of this, stated with the estimate: 85%; the middle value sits exactly at the limit.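

For the compounds shown here, no step from compound 1, compound 2 or compound 3 to compound 4 can be read, because all four share one result: the limit of > 200000 nM in this assay, at which 4 of the 4 values shown sit. The compounds shown leave open whether any of these substituent changes alters cytotoxicity, as they give no graded value.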